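This account rests on a few compounds, and the source may have more. Where it says the series, first, only, none or still open, it means among the compounds named here.

Measured compounds:
- compound 1, `CS/C(=N\C(=O)c1sccc1Cl)NC(=O)c1sccc1Cl`: 57400 nM
- compound 2, `CS/C(=N\C(=O)c1csc([N+](=O)[O-])c1)NC(=O)c1csc([N+](=O)[O-])c1`: 82500 nM

Both compounds were tested in a functional assay on PC-3 cells (Homo sapiens) for cytotoxicity, read by MTT assay, with a stated time of 72 h; a lower number here means a stronger inhibitor of growth, a higher number a weaker inhibitor of growth. In this assay compound 1 gives 57400 nM, and compound 2 gives 82500 nM. Compound 2 has the higher of the two numbers, but the gap to compound 1 is within the scatter of repeated measurements, so the two cannot be told apart on these data. Among the compounds with values here, the two compounds share a core with the same central carbon doubly bonded to nitrogen and two amide-type nitrogens; they differ in the thiophene substituents, and no step between them is counted here.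

Compound 3, `O=C(/N=C(/NC(=O)c1csc([N+](=O)[O-])c1)[Se]Cc1ccccc1)c1csc([N+](=O)[O-])c1`, has not yet been measured in this assay. It keeps the nitro-substituted thiophene amides of compound 2 and changes one place: a group of 8 heavy atoms (7 carbon, 1 selenium; one six-membered aromatic ring of carbon only) in place of a group of 2 heavy atoms (1 carbon, 1 sulfur; no ring), on a carbon with a double bond to nitrogen. Within the data shown here, no measured pair in this set shows what such a change does, so there is nothing to anchor the size or the direction of the step. The expectation is therefore a step from compound 2 to compound 3 of about a 1.3-fold lower number from compound 2 to compound 3 (0.10 log units; within the scatter), that is, no change beyond the scatter, with wide uncertainty either way. Compound 3 is expected to give 65000 nM, in a range from 15000 nM to 250000 nM.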

Compound 3, concentration for total growth inhibition: 69200 nM
Estimate against measurement, compound 3: 1.1-fold (0.03 log units) below; low and high end bracket the measured number.
By their numbers in this assay, from the lowest: compounds 1, 3 and 2 (each within the scatter of the next).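

In this assay, within the data shown here, the only pair of compounds that differ in one place gives a 1.2-fold lower number from compound 2 to compound 3 (0.08 log units; within the scatter). At this carbon with a double bond to nitrogen, whose other neighbours are two amide-type nitrogens, methylsulfanyl can therefore give way to a group of 8 heavy atoms, with selenium and a six-membered aromatic ring of carbon only, and the number stays within the scatter; compound 1 and compound 2 could not show this, since both carry methylsulfanyl and differ only elsewhere. No measurement in hand explains this outcome.

Going by these compounds, the change brings in selenium and the ring at the same time, so the effect of each alone stays unknown, and the small step could hide two opposing contributions or reflect none at all. Also open, on these data alone, is how the number would respond at this carbon to an amine or a longer carbon chain, and whether the same tolerance would appear with the chlorine-bearing amides of compound 1.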